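A few compounds are considered here, and "the series" means these few. Any claim that something is new, unique, unknown or untested is made for them only; others in the source may bear on it.

Measured compounds:
- Compound 1 `CC(C)OC(=O)N1CCC2(CC1)CC(CCCOc1ccc(S(C)(=O)=O)c(F)c1)C2`, in a physicochemical assay for solubility, read by HPLC, in phosphate buffer, with a stated time of 24 h, at pH 6.8; on this read-out lower numbers stand for lower solubility and higher numbers for higher solubility: < 0.16 ug/mL, a limit of the assay.
- Compound 2 `CC1(OC(=O)N2CCC3(CC2)CC(CCCOc2ccc(S(C)(=O)=O)c(F)c2)C3)CC1`, in this assay: < 0.15 ug/mL, also a limit.

Compound 1 stands at a limit only; of the two values shown, the other is a limit as well, so no number places it. For the measured compounds named here, the one measured step, a step that the two limits leave unreadable from compound 1 to compound 2, is a change of 1-methylcyclopropyl for isopropyl on an oxygen next to a carbonyl group, and it cannot be read because the limit of < 0.16 ug/mL in this assay, at which 1 of the 2 values shown sits, and the limit of < 0.15 ug/mL in this assay, at which 1 of the 2 values shown sits, cap both ends.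

Compound 3 `CC(C)OC(=O)N1CCC2(CC1)CC(CCCOc1ccc(C(=O)NC3CC3)c(F)c1)C2` differs from compound 1 by cyclopropylcarbamoyl in place of methylsulfonyl on an aromatic carbon. No measured step touches this position, so nothing shown gauges it; the step of an at least 3.1-fold higher number from compound 1 to compound 3 (0.49 log units; beyond the scatter) is estimated from the starting limit alone and may be unreadable again. Compound 3 is expected to give about 0.5 ug/mL, within 0.1 ug/mL to 3 ug/mL.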

Compound 3, solubility: 0.21 ug/mL
For compound 3 the middle estimate is 2.4-fold (0.38 log units) above the measured one; the range from low to high includes it.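

In this assay, the change to cyclopropylcarbamoyl at this position, para to a large group and ortho to a fluoro group, gives the first step shown that ends on a number instead of a limit: an at least 1.3-fold higher number from compound 1 to compound 3 (0.11 log units; that floor lies within the scatter). For the compounds shown here, compound 3 gives 0.21 ug/mL, the only value shown that is not a limit. The step is only a floor because it starts from compound 1, whose value is a limit: the limit of < 0.16 ug/mL in this assay, at which 1 of the 3 values shown sits.

As far as these compounds go, the true size of that step stays open, and the step between the two compounds that both sit at limits cannot be read. Also open, from the compounds shown here alone, is how an amine or a carboxylic acid on this aromatic carbon would read in this assay, and whether cyclopropylcarbamoyl gives a readable value with 1-methylcyclopropyl in place of isopropyl.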